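The source may hold more compounds than are shown below. What is called first, only, known or untested is meant among the compounds shown, and "the series" means these compounds.

Measured so far in a functional assay on MDA-MB-231 cells (Homo sapiens) for inhibition, read by MTT assay, with a stated time of 72 h; on this read-out lower numbers stand for stronger inhibition and higher numbers for weaker inhibition:
compound 1 `CC(C)(C)n1cc2c(n1)C(=O)CC1(CCN(C(=O)c3cc(-c4ccccc4Cl)nc4ccccc34)CC1)O2`: > 10000 nM
compound 2 `CC(C)(C)n1cc2c(n1)C(=O)CC1(CCN(C(=O)c3cc(-c4ccc(N)cc4)nc4ccccc34)CC1)O2`: 4960 nM
compound 3 `CC(C)(C)n1cc2c(n1)C(=O)CC1(CCN(C(=O)c3cc(-c4ccncc4)nc4ccccc34)CC1)O2`: 1650 nM

The value of compound 1 in this assay is a limit of the assay, not a number (the limit of > 10000 nM in this assay, at which 1 of the 3 values shown sits). The two steps that leave compound 1 both exchange the 2-chlorophenyl for another aromatic ring: an at least 2.0-fold lower number from compound 1 to compound 2 (0.30 log units; that floor lies within the scatter), and an at least 6.0-fold lower number from compound 1 to compound 3 (0.78 log units; beyond the scatter). Between those two aryl replacements, a 3.0-fold lower number from compound 2 to compound 3 (0.48 log units; beyond the scatter).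

Compound 4 `Cc1cc(C(=O)N2CCC3(CC2)CC(=O)c2nn(C(C)(C)C)cc2O3)c2ccccc2n1` differs from compound 1 in the same place: methyl in place of 2-chlorophenyl on an aromatic carbon. No measured step exchanges the 2-chlorophenyl for a group without a ring, so the aryl steps bear on compound 4 only insofar as every departure from the 2-chlorophenyl so far has lowered the number; whether a methyl does the same is not shown by the three compounds at hand, and the exchange of a seven-heavy-atom ring for a single carbon is a larger structural change than either measured step. The expectation is an at least 1.6-fold lower number from compound 1 to compound 4 (0.22 log units; that floor lies within the scatter), toward a lower number, held with wide uncertainty and with a real chance that compound 4 again reaches only the limit. Compound 4 is estimated at 6000 nM, within 1500 nM to 20000 nM.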

Compound 4, half-maximal inhibitory concentration: 4860 nM
Compound 4: middle estimate off by 1.2-fold (0.09 log units), on the high side; measured number inside the range.
By their numbers in this assay, from the lowest: compound 3; then compounds 4 and 2 (each within the scatter of the next). At a limit, above all of these: compound 1.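

In this assay, a ring at this position, next to the ring nitrogen, turns out not to be required for a number of this order: there is a 1.0-fold lower number from compound 2 to compound 4 (0.01 log units; within the scatter) and the single methyl cannot be told apart from the 4-aminophenyl. For the compounds shown here, compound 3 remains the only compound clearly separated from the methyl on the low side, with a 2.9-fold higher number from compound 3 to compound 4 (0.47 log units; beyond the scatter) on going to the smaller group, while the 2-chlorophenyl lies on the other side, with an at least 2.0-fold lower number from compound 1 to compound 4 (0.31 log units; beyond the scatter) on the same change. The value of compound 1 is a limit of the assay, and the step from it is a floor only: the limit of > 10000 nM in this assay, at which 1 of the 4 values shown sits.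

A plain phenyl or a pyridin-3-yl at this position would show whether the separation of compound 3 follows the ring nitrogen of the pyridin-4-yl or its place in the ring. Also open, from the compounds shown here alone, is how an ethyl, a longer chain or a small amine such as dimethylamino would compare with the methyl, and whether the limit of compound 1 goes with the chlorine or with the phenyl ring that carries it.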